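Trading chloro for amino at a fixed chain

The compounds below may be only part of what the source reports. "The series", "measured", "known", "first", "only" and "open" are said of these compounds alone.

Among the three compounds measured in a functional assay on SW480 cells (Homo sapiens) for antiproliferative activity, read by MTT assay, with a stated time of 48 h (on this read-out higher numbers stand for weaker inhibition and lower numbers for stronger inhibition), compound 3 (`CCCCCCCCCC(CCO)n1cnc2c(Cl)ncnc21`) gives 1150 nM as the lowest number. Compound 2 (`CCCCCCCCC(CCO)n1cnc2c(N)ncnc21`) gives 20700 nM as the nearest value and stands clearly higher. Compound 1 (`CCCCCCCC(CCO)n1cnc2c(N)ncnc21`) gives only a limit of > 50000 nM in this assay and no number.

Compound 4 (`CCCCCCCCCC(CCO)n1cnc2c(N)ncnc21`) has yet to be measured. The change from compound 3 to compound 4 is amino in place of chloro on an aromatic carbon and amounts to amino in place of chloro on an aromatic carbon. Within the data shown here, no measured step makes this swap directly. Among the measured compounds shown here, the one measured step is an at least 2.4-fold lower number from compound 1 to compound 2 (0.38 log units; beyond the scatter) and it lies in the chain, so it bears on this change only indirectly. That step points to a lower number as the chain of the amino compounds grows. Compound 4 shares its amino group with compound 2, which stands at 20700 nM on this read-out, and its chain with compound 3, which stands at 1150 nM here. A position between these two values, closer to compound 2, is therefore expected.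

The estimated change is a 7.8-fold higher number from compound 3 to compound 4 (0.89 log units; beyond the scatter) and would lie beyond the scatter, towards weaker inhibition. Compound 4 is estimated at 9000 nM in this assay with an expected range from 3500 nM to 25000 nM around that figure.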

Compound 4, half-maximal inhibitory concentration: 6030 nM
For compound 4 the middle estimate is 1.5-fold (0.17 log units) above the measured one; the range from low to high includes it.
By their numbers in this assay, from the lowest: compound 3; then compound 4; then compound 2. At a limit, above all of these: compound 1.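

In this assay, the direct swap of amino in place of chloro on this aromatic carbon, with the chain held fixed, gives a 5.2-fold higher number from compound 3 to compound 4 (0.72 log units; beyond the scatter), so at this chain length the group at this position alone moves the number beyond the scatter. Among the amino compounds, the chain step a 3.4-fold lower number from compound 2 to compound 4 (0.54 log units; beyond the scatter) runs in the same direction as the earlier chain step, which shows that the chain and the group at this position each shift the number on their own. Compound 1 is given only as a limit, so an at least 8.2-fold lower number from compound 1 to compound 4 (0.91 log units; beyond the scatter) reads as a bound and not as a measured size: the limit of > 50000 nM in this assay, at which 1 of the 4 values shown sits.

Chloro appears here with one chain only, so it remains open whether the chain steps seen among the amino compounds carry over to the chloro compounds, or whether a longer chain would lower the number further. Going by these compounds, the standing of other groups at this aromatic carbon, such as bromo, methoxy or methylamino, also remains open, as does the effect of a carboxylic acid in place of the hydroxyl at the end of the chain.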